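This account rests on a few compounds, and the source may have more. Where it says the series, first, only, none or still open, it means among the compounds named here.

The series shares one core, seen in compound 1 `Cc1nc(C)c(/C=C/C(=O)c2ccc(NC(=O)c3ccccc3F)cc2)nc1C`, compound 2 `COc1cccc(OC)c1C(=O)Nc1ccc(C(=O)/C=C/c2nc(C)c(C)nc2C)cc1` and compound 3 `Cc1nc(C)c(/C=C/C(=O)c2ccc(NC(=O)c3ccc(F)cc3)cc2)nc1C`; they differ only in the aryl group on a carbonyl carbon whose other neighbour is an amide-type nitrogen. In a functional assay on MCF7 cells (Homo sapiens) for antiproliferative activity, read by CCK-8 assay, with a stated time of 72 h (a lower number here means a stronger inhibitor, a higher number a weaker inhibitor), compound 2 gives 2470 nM, the highest of the three numbers, while compound 1 gives 1270 nM and compound 3 gives 1540 nM; both gaps lie within the scatter, so no order among them can be claimed. Compound 4 `COc1ccc(C(=O)Nc2ccc(C(=O)/C=C/c3nc(C)c(C)nc3C)cc2)cc1` has not yet been measured. It differs from compound 2 as follows: 4-methoxyphenyl in place of 2,6-dimethoxyphenyl on a carbonyl carbon. For the measured compounds named here, the steps that bear on this are a 1.9-fold higher number from compound 1 to compound 2 (0.29 log units; within the scatter) and a 1.6-fold lower number from compound 2 to compound 3 (0.21 log units; within the scatter), each a swap of the same aryl group and each within the scatter. A move from 2,6-dimethoxyphenyl to 4-methoxyphenyl is therefore expected to shift this assay little, if at all, perhaps toward a somewhat lower number, as seen with compound 3 at 1540 nM. Compound 4 is estimated at 1700 nM, with a range of 700 nM to 4500 nM, a step of a 1.5-fold lower number from compound 2 to compound 4 (0.16 log units; within the scatter) that is expected to remain within the scatter.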

Compound 4, half-maximal inhibitory concentration: 1410 nM
For compound 4 the middle estimate is 1.2-fold (0.08 log units) above the measured one; low and high end bracket the measured number.
By their numbers in this assay, from the lowest: compounds 1, 4, 3 and 2 (each within the scatter of the next).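

In this assay, the 4-methoxyphenyl group on this carbonyl carbon gives a 1.8-fold lower number from compound 2 to compound 4 (0.24 log units; within the scatter), a 1.1-fold lower number from compound 3 to compound 4 (0.04 log units; within the scatter) and a 1.1-fold higher number from compound 1 to compound 4 (0.05 log units; within the scatter), and each of these steps lies within the scatter. The earlier compounds shown here compared only the 2-fluorophenyl, 4-fluorophenyl and 2,6-dimethoxyphenyl groups, so this adds a fourth aryl group and a direct swap of methoxy for fluoro on an aromatic carbon, and no step among the four compounds can be read as a real difference. Nothing measured here offers an explanation for this flat result.

The compounds shown leave open whether an amine or a carboxylic acid on this aryl group, or a longer alkyl chain in its place, would move the number beyond the scatter. They also leave open whether these four aryl groups would stay as close in other cell lines.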